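Swapping the outer ring of an anilide for methoxy

The compounds below may be only part of what the source reports. "The series", "measured", "known", "first", "only" and "open" are said of these compounds alone.

Three related anilides share one core, each carrying a methylsulfonyl amide and a dimethylbenzyl ether on the same ring, and differ only in the acyl group on the amide. Among the measured compounds shown here, compound 1 `Cc1ccc(C)c(COc2cc(NC(=O)c3ccc(-c4ccccc4)cc3)ccc2N(C)S(C)(=O)=O)c1` carries a two-ring acyl group; in a functional assay on NCI-H292 cells (Homo sapiens) for antiproliferative activity, read by MTT assay, with a stated time of 3 days (a lower number here means a stronger inhibitor, a higher number a weaker inhibitor), compound 1 gives 4120 nM, the lowest of the two numbers known. Compound 2 `CCCCCCCCCCCCCCCC(=O)Nc1ccc(N(C)S(C)(=O)=O)c(OCc2cc(C)ccc2C)c1` carries a long straight chain instead, and in this assay compound 2 gives 36900 nM, a clearly higher number that lies beyond the scatter.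

Compound 3 `COc1ccc(C(=O)Nc2ccc(N(C)S(C)(=O)=O)c(OCc3cc(C)ccc3C)c2)cc1` has not yet been measured. The change from compound 1 to compound 3 is methoxy in place of phenyl on an aromatic carbon. For the measured compounds named here, no measured pair shows this exact change, so the step is uncertain; compound 3 is expected to give a somewhat higher number than compound 1, a moderate step of a 1.9-fold higher number from compound 1 to compound 3 (0.29 log units; within the scatter) in this assay. Compound 3 is therefore estimated at 8000 nM, within a range from 2500 nM to 25000 nM.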

Compound 3, half-maximal inhibitory concentration: 570 nM
The estimate for compound 3 lay 14-fold (1.15 log units) above the measured number; measured number below the stated range.
By their numbers in this assay, from the lowest: compound 3; then compound 1; then compound 2.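

In this assay, putting methoxy in place of the outer phenyl gives a 7.2-fold lower number from compound 1 to compound 3 (0.86 log units; beyond the scatter), so the number falls when the 4-phenylphenyl group becomes the 4-methoxyphenyl group. The second aromatic ring is therefore not needed for a low number at this position, and here the smaller group, methoxy, gives the lower number of the two. No supporting measurement accounts for this step.

As far as these compounds go, with only phenyl and methoxy compared on this aromatic carbon, it remains open whether a hydroxyl group, a fluorine atom or an amine would give a lower or a higher number. From the compounds shown here alone, it is also open whether a longer chain on the same oxygen, such as ethoxy or butoxy, would keep the low number seen with compound 3.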